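Halogen swap on the pendant phenyl of compound 2

This account rests on a few compounds, and the source may have more. Where it says the series, first, only, none or still open, it means among the compounds named here.

Compound 1 `COc1cc2c(Oc3ccc(NC(=O)c4nn(-c5ccccc5)c(=O)c5ccccc45)cc3F)ccnc2cc1OCCCN1CCC(C)CC1` gives 1040 nM in a functional assay on HT-29 cells (Homo sapiens) for cytotoxicity, read by MTT assay, with a stated time of 72 h; a lower number here means a stronger inhibitor, a higher number a weaker inhibitor.
Compound 2 `COc1cc2c(Oc3ccc(NC(=O)c4nn(-c5ccccc5F)c(=O)c5ccccc45)cc3F)ccnc2cc1OCCCN1CCC(C)CC1` gives 510 nM in this assay.

For the measured compounds named here, compound 2 stands lowest of the two numbers measured so far; its only neighbour is compound 1, separated by the step of a 2.0-fold lower number from compound 1 to compound 2 (0.31 log units; beyond the scatter). Compound 3 `COc1cc2c(Oc3ccc(NC(=O)c4nn(-c5ccc(Br)cc5)c(=O)c5ccccc45)cc3F)ccnc2cc1OCCCN1CCC(C)CC1` is the next case, with the change (4-bromophenyl in place of 2-fluorophenyl on an aromatic nitrogen). Going by the values given here, the single measured step, a 2.0-fold lower number from compound 1 to compound 2 (0.31 log units; beyond the scatter), concerns fluoro in place of hydrogen on an aromatic carbon and so bears on this change only loosely; no measured step speaks to a bromine or to a 4-substituted phenyl at this place. The step from compound 2 to compound 3 in this assay is therefore expected to be about a 1.4-fold higher number from compound 2 to compound 3 (0.14 log units; within the scatter), which is expected to stay within the scatter. Compound 3 is estimated at 700 nM, with a range from 300 nM to 1800 nM.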

Compound 3, half-maximal inhibitory concentration: 920 nM
Estimate against measurement, compound 3: 1.3-fold (0.12 log units) below; measured number inside the range.
By their numbers in this assay, from the lowest: compounds 2, 3 and 1 (each within the scatter of the next, the first and the last beyond it).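

In this assay, 4-bromophenyl in place of 2-fluorophenyl on the aromatic nitrogen gives a 1.8-fold higher number from compound 2 to compound 3 (0.26 log units; within the scatter), so these two compounds cannot be told apart. Bromo in place of hydrogen gives a 1.1-fold lower number from compound 1 to compound 3 (0.05 log units; within the scatter), which also stays within the scatter, so here a halogen on the phenyl does not separate from hydrogen; compound 2 goes against this, as a 2.0-fold lower number from compound 1 to compound 2 (0.31 log units; beyond the scatter) is the only step beyond the scatter. No measured finding explains these results.

This change replaces the halogen and moves it on the phenyl at once, so the compounds shown cannot assign the small step to either. They also leave open how an amine or a carboxylic acid on this phenyl would read in this assay.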